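The compounds below may be only part of what the source reports. "The series", "measured", "known", "first", "only" and "open" are said of these compounds alone.

Measured so far:
- Compound 1 `Nc1scc(CN2CCN(c3cccc4ccccc34)CC2)c1C(=O)c1ccc(Cl)cc1`: -21%
- Compound 2 `Nc1scc(CN2CCN(c3cc(F)cc(F)c3)CC2)c1C(=O)c1ccc(Cl)cc1`: -79%

Both numbers come from a functional assay on CHO cells with adenosine receptor A1 (Homo sapiens) as the target, read by cAMP accumulation and immunoassay, with a stated time of 6 min, tested at 10 uM; on this read-out higher numbers stand for a weaker effect at the one concentration tested and lower numbers for a stronger effect. Compound 2 stands lowest of the two, and its nearest neighbour is compound 1, whose number lies higher by more than the scatter. Going by the values given here, the single step available, a number 58 percentage points lower from compound 1 to compound 2 (beyond the scatter), is large and shows that the group on the ring nitrogen of the shared core moves the read-out strongly.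

Compound 3 `Nc1scc(CN2CCN(c3cccc(F)c3F)CC2)c1C(=O)c1ccc(Cl)cc1` differs from compound 2 only at that same ring nitrogen: 2,3-difluorophenyl in place of 3,5-difluorophenyl on an amine nitrogen in a ring. Among the compounds with values here, the measured step concerns an exchange of a whole aryl group for another, whereas here the two fluorines are merely placed differently on the same phenyl; no measured pair shows such a rearrangement, so the direction is not fixed by the data. Given that the only shown step at this position is large, a move of moderate size, most likely back toward a higher number, is expected, a number 19 percentage points higher from compound 2 to compound 3 (beyond the scatter).

Compound 3 is therefore estimated at -60% in this assay, with a range from -90% to -20%.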

Compound 3, a percentage reported as activity, at one concentration (the size of the read-out at that concentration, not a potency): -79%
Compound 3: the middle estimate sits 19 percentage points above what was measured, within the range that was stated.
By their numbers in this assay, from the lowest: compounds 2 and 3 (each within the scatter of the next); then compound 1.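

In this assay the rearrangement of the two fluorines on the phenyl gives no change at the digits printed from compound 2 to compound 3 (within the scatter) and so, on the amine nitrogen in the ring, this read-out does not separate 3,5-difluorophenyl from 2,3-difluorophenyl. The large step away from naphthalen-1-yl also no longer rests on one difluorophenyl group alone: the second difluorophenyl compound shows a number 58 percentage points lower from compound 1 to compound 3 (beyond the scatter) and matches in size the step seen earlier, so both placements of fluorine part from compound 1 alike. No measurement at hand bears on why the two placements read alike or why both differ from naphthalen-1-yl.

As far as these compounds go, whether a plain phenyl or a methoxyphenyl on the same ring nitrogen would read with the two difluorophenyl compounds or with compound 1 remains open, and with it whether the fluorines matter at all or only the size of the aryl group. Also open, from the compounds shown here alone, is whether full concentration series would separate compound 2 and compound 3, which a single-concentration read-out cannot settle.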